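The compounds below may be only part of what the source reports. "The series", "measured", "known", "first", "only" and "open" are said of these compounds alone.

Measured so far in a functional assay on MCF7 cells (Homo sapiens) for antiproliferative activity, read by MTT assay, with a stated time of 48 h; a lower number here means a stronger inhibitor, a higher number a weaker inhibitor:
compound 1 `Cc1ccccc1-n1nncc1CN1C(=O)C2(C(C#N)=C(N)Oc3c(N)cc4nc5ccccc5nc4c32)c2ccccc21` reads > 50000 nM, a limit of the assay and not a number.
compound 2 `N#CC1=C(N)Oc2c(N)cc3nc4ccccc4nc3c2C12C(=O)N(Cc1cnnn1-c1cccc(C(F)(F)F)c1)c1ccccc12` reads 31600 nM.
compound 3 `CCOc1ccccc1-n1nncc1CN1C(=O)C2(C(C#N)=C(N)Oc3c(N)cc4nc5ccccc5nc4c32)c2ccccc21` reads > 50000 nM, likewise a limit and not a number.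

Compound 3 therefore stands only at a limit, and it shares that limit with compound 1 (the limit of > 50000 nM in this assay, at which 2 of the 3 values shown sit). Within the data shown here, compound 2 is the sole member of the series with a number, and that number lies close to the limit. The step of an at least 1.5-fold higher number from compound 2 to compound 3 (0.19 log units; that floor lies within the scatter) is accordingly known only by its floor, and the step of an at least 1.5-fold lower number from compound 1 to compound 2 (0.19 log units; that floor lies within the scatter) by the same kind of floor; the step that the two limits leave unreadable from compound 1 to compound 3 cannot be read at all, since both ends are limits.

The next compound 4 `N#CC1=C(N)Oc2c(N)cc3nc4ccccc4nc3c2C12C(=O)N(Cc1cnnn1-c1cc(Cl)ccc1Cl)c1ccccc12` changes the same position once more: 2,5-dichlorophenyl in place of 2-ethoxyphenyl on an aromatic nitrogen. The two readable steps on this position, both exchanges of the aryl group on the aromatic nitrogen, are each at most a floor that sits within the scatter, so nothing among the three measured compounds points to a shift larger than the scatter in either direction. Compound 4 is therefore expected to fall near the limit, with an at least 1.2-fold lower number from compound 3 to compound 4 (0.09 log units; that floor lies within the scatter) as the estimated step, and a considerable chance that the assay again returns only a limit. The estimate for compound 4 in this assay is 40000 nM, within 18000 nM to 100000 nM.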

Compound 4, half-maximal inhibitory concentration: 33200 nM
Beside the measured number, compound 4's estimate is 1.2-fold (0.08 log units) above it; the range from low to high includes it.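

The series now holds its first step with a number at both ends, a 1.1-fold higher number from compound 2 to compound 4 (0.02 log units; within the scatter) in this assay, so 2,5-dichlorophenyl and 3-(trifluoromethyl)phenyl on the aromatic nitrogen read alike. The steps from the two compounds held at a limit remain floors, an at least 1.5-fold lower number from compound 3 to compound 4 (0.17 log units; that floor lies within the scatter) and an at least 1.5-fold lower number from compound 1 to compound 4 (0.17 log units; that floor lies within the scatter), and neither establishes a change beyond the scatter. Across the four compounds, the two that give a number carry chlorine or trifluoromethyl on the aryl ring, while compound 1 with 2-methylphenyl and compound 3 with 2-ethoxyphenyl stay at a limit, so this split rests only on such floors and on that shared limit: the limit of > 50000 nM in this assay, at which 2 of the 4 values shown sit.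

On these data alone, whether the aryl group on this nitrogen can move the read-out clearly beyond the scatter remains open, as neither of the two numbers in this assay stands far from that limit. An aryl ring bearing an amine or a carboxylic acid, or a longer alkyl chain in place of the aryl ring, would test whether this position tolerates anything that gives a markedly lower number.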